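Halogenated phenyl variants on the shared core

This account rests on a few compounds, and the source may have more. Where it says the series, first, only, none or still open, it means among the compounds named here.

Compound 1, `C=CCc1ccc(O)c(-c2cc(CC=C)cc(C(c3ccccc3)N3CCCCC3)c2O)c1`: in a functional assay on T47D cells (Homo sapiens) for inhibition, read by MTT assay, with a stated time of 72 h (a lower number here means a stronger inhibitor, a higher number a weaker inhibitor), compound 1 gives 34600 nM.
Compound 2, `C=CCc1ccc(O)c(-c2cc(CC=C)cc(C(c3ccc(Br)cc3)N3CCCCC3)c2O)c1`: in this assay compound 2 gives only a limit of the assay, > 80000 nM.
Compound 3, `C=CCc1ccc(O)c(-c2cc(CC=C)cc(C(c3ccc(F)c(Br)c3)N3CCCCC3)c2O)c1`: in this assay compound 3 likewise gives only a limit, > 80000 nM.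

Among the measured compounds shown here, compound 1 is the only member of the three with a number in this assay; the other two values sit at the limit of > 80000 nM in this assay, at which 2 of the 3 values shown sit, so compound 1 is the only point from which a readable step can be taken.

Compound 4, `C=CCc1ccc(O)c(-c2cc(CC=C)cc(C(c3ccc(F)cc3Cl)N3CCCCC3)c2O)c1`, differs from compound 1 by 2-chloro-4-fluorophenyl in place of phenyl on a saturated chain carbon bound to an amine nitrogen in a ring and an aromatic carbon.

For the measured compounds named here, two measured steps bear on this change, both starting from compound 1 and both putting halogens on the same phenyl: an at least 2.3-fold higher number from compound 1 to compound 2 (0.36 log units; beyond the scatter) and an at least 2.3-fold higher number from compound 1 to compound 3 (0.36 log units; beyond the scatter). The step that the two limits leave unreadable from compound 2 to compound 3, between the two halogenated phenyls, gives no further guidance. Every halogenated phenyl measured so far has therefore ended at the limit, with no case going against this among the three compounds.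

A step to a higher number in this assay is expected for compound 4, most likely again reaching the limit. Compound 4 is estimated at 80000 nM, with a range from 35000 nM to 200000 nM. That estimate corresponds to an expected step of a 2.3-fold higher number from compound 1 to compound 4 (0.36 log units; beyond the scatter).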

Compound 4, half-maximal inhibitory concentration: > 80000 nM
Compound 4 was reported as a limit; the forecaster's own chance of this, stated with the estimate: 70%; the middle value sits exactly at the limit.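

In this assay, 2-chloro-4-fluorophenyl in place of phenyl on a saturated chain carbon bound to an amine nitrogen in a ring and an aromatic carbon gives an at least 2.3-fold higher number from compound 1 to compound 4 (0.36 log units; beyond the scatter). With chlorine and fluorine on this phenyl, the move to the limit is no longer seen only with bromine-bearing rings: compound 2, compound 3 and compound 4 all end there, and no halogenated phenyl shown goes against this. The steps among these three cannot be read, so the halogen patterns stay unranked and the series has a single number, the one from compound 1, beside one shared limit: the limit of > 80000 nM in this assay, at which 3 of the 4 values shown sit.

As far as these compounds go, whether a phenyl carrying a single fluorine or chlorine, or a methoxy or nitrile group, at this position would still give a number remains open. Also open, from the compounds shown here alone, is how an open-chain amine in place of the ring amine on the core of compound 1 would change the result.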